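Fluoro on the benzyl group of a nitro sulfonate

A few compounds are considered here, and "the series" means these few. Any claim that something is new, unique, unknown or untested is made for them only; others in the source may bear on it.

compound 1 `COc1ccc(S(=O)(=O)Oc2ccccc2/C=C(\C#N)C(=O)Nc2nnc(Cc3ccccc3)s2)cc1`: 100%
compound 2 `N#C/C(=C\c1ccccc1OS(=O)(=O)c1ccc([N+](=O)[O-])cc1)C(=O)Nc1nnc(Cc2ccccc2)s1`: 20%
compound 3 `N#C/C(=C\c1ccccc1OS(=O)(=O)c1ccccc1[N+](=O)[O-])C(=O)Nc1nnc(Cc2ccccc2)s1`: 12%

In a functional assay on HL-60 cells (Homo sapiens) for inhibition, read by CCK-8 assay, with a stated time of 48 h, tested at 20 uM (a higher number here means more inhibition of growth at the concentration tested, a lower number less inhibition of growth), compound 2 gives 20%. This lies within the scatter of compound 3, as a number 8 percentage points lower from compound 2 to compound 3 (within the scatter) shows, and far under compound 1, as a number 80 percentage points lower from compound 1 to compound 2 (beyond the scatter) shows. Compound 4 `N#C/C(=C\c1ccccc1OS(=O)(=O)c1ccc([N+](=O)[O-])cc1)C(=O)Nc1nnc(Cc2cccc(F)c2)s1` differs from compound 2 by fluoro in place of hydrogen on an aromatic carbon, which turns benzyl into 3-fluorobenzyl. The measured steps all change the group on the sulfonyl sulfur, including the large a number 88 percentage points lower from compound 1 to compound 3 (beyond the scatter). None touches the benzyl group, so they give no direct size for this change, and no step beyond the scatter is the likeliest outcome. The expected result is a number 5 percentage points higher from compound 2 to compound 4 (within the scatter). The estimate for compound 4 is 25%, within an expected range from 8% to 55%.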

Compound 4, percent growth inhibition at one concentration: 18%
Estimate against measurement, compound 4: 7 percentage points above, within the range that was stated.
By their numbers in this assay, from the lowest: compounds 3, 4 and 2 (each within the scatter of the next); then compound 1.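

In this assay, within the data shown here, 3-fluorobenzyl in place of benzyl gives a number 2 percentage points lower from compound 2 to compound 4 (within the scatter), the first reading at this position, since the earlier steps all changed the group on the sulfonyl sulfur. With the 4-nitrophenyl group on the sulfonyl sulfur, fluoro on this aromatic carbon thus produces no step beyond the scatter. Nothing on hand bears on the reason for this result.

From the compounds shown here alone, whether fluoro would read the same alongside the 4-methoxyphenyl group of compound 1 remains open. So does the effect of an amine or a carboxylic acid on the benzyl group, or of a longer chain in its place.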